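Chloro for Methyl: an Expectation for Compound 4

The source may report more compounds than this note shows. Statements on the series, on what has been measured and on what is new or still open speak of the compounds shown alone.

Of the compounds shown here, three have been measured in a functional assay for inhibition of sodium/hydrogen exchanger (Oryctolagus cuniculus); on this read-out lower numbers stand for stronger inhibition and higher numbers for weaker inhibition. Compound 1 `Cc1c(C(=O)N=C(N)N)cc(S(C)(=O)=O)c(Cl)c1Cl` gives 29 nM, compound 2 `Cc1c(C(=O)N=C(N)N)cc(S(C)(=O)=O)c(Cl)c1C` gives 58 nM, and compound 3 `Cc1cc(Nc2ncccn2)c(S(C)(=O)=O)cc1C(=O)N=C(N)N` gives 8.3 nM, the lowest number of the three. Compound 1 and compound 2 differ by chloro in place of methyl on an aromatic carbon, and the step is a 2.0-fold lower number from compound 2 to compound 1 (0.30 log units; within the scatter). How the core of compound 3 differs from that of compound 2 is not broken down here.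

Compound 4 `CS(=O)(=O)c1cc(C(=O)N=C(N)N)c(Cl)cc1Nc1ncccn1` is not yet measured. It differs from compound 3 by chloro in place of methyl on an aromatic carbon. Going by the values given here, this is the same kind of change as the one from compound 2 to compound 1, but its surroundings differ: in compound 1 the new chloro sits ortho to a chloro group and ortho to a methyl group, meta to a group of 6 heavy atoms and meta to a methylsulfonyl group, whereas in compound 4 it sits ortho to a group of 6 heavy atoms, meta to a (pyrimidin-2-yl)amino group and para to a methylsulfonyl group.

The author expects a step of about a 1.4-fold lower number from compound 3 to compound 4 (0.14 log units; within the scatter), resting on a 2.0-fold lower number from compound 2 to compound 1 (0.30 log units; within the scatter), which is within the scatter. For compound 4 the estimated value in this assay is 6 nM, expected between 2.5 nM and 15 nM.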

Compound 4, half-maximal inhibitory concentration: 49 nM
Estimate against measurement, compound 4: 8.2-fold (0.91 log units) below; measured number outside the range, above it.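

In this assay, chloro in place of methyl on an aromatic carbon gives a 5.9-fold higher number from compound 3 to compound 4 (0.77 log units; beyond the scatter), a step toward weaker inhibition that lies beyond the scatter. Set beside the earlier step, the same change does not read alike on the two cores: the same change on two cores in this assay, a 2.0-fold lower number (0.30 log units; within the scatter) from compound 2 to compound 1 and a 5.9-fold higher number (0.77 log units; beyond the scatter) from compound 3 to compound 4, 12-fold (1.07 log units) apart, beyond the scatter of two such steps. Going by these compounds alone, this shows that, in this series, the step seen on the core of compound 1 could not be carried over to the core of compound 4, but with only two pairs it gives no general rule and does not show which of the many differences between the two cores and the surroundings of the change sets the steps apart.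

The compounds shown leave open whether the (pyrimidin-2-yl)amino group is the part that matters, which a matched methyl and chloro pair carrying a simple amine in its place could address. They also leave open how a bromo or methoxy group would read at the place of the chloro on the core of compound 4.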